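The source may report more compounds than this note shows. Statements on the series, on what has been measured and on what is new or still open speak of the compounds shown alone.

Compounds measured in a functional assay on RAW264.7 cells (Mus musculus) for inhibition, with stated times of 1 h and 24 h; a higher number here means a weaker inhibitor, a lower number a stronger inhibitor:
- compound 1 `COc1cc2oc(-c3cccc(C(=O)Nc4ccccc4)c3)cc(=O)c2c(OC)c1OC`: "not determined" (no result reported)
- compound 2 `COc1ccccc1NC(=O)c1cccc(-c2cc(=O)c3c(OC)c(OC)c(OC)cc3o2)c1`: 1990 nM
- compound 3 `COc1cccc(NC(=O)c2cccc(-c3cc(=O)c4c(OC)c(OC)c(OC)cc4o3)c2)c1`: "not determined" (no result reported)

Only one of these three amides has a number in this assay. Compound 3 cannot be placed on the scale, since its entry reads "not determined" (no result reported), and compound 1 is in the same position. That leaves compound 2, at 1990 nM, as the sole point of reference.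

The next compound to be tested is compound 4 `COc1cc(NC(=O)c2cccc(-c3cc(=O)c4c(OC)c(OC)c(OC)cc4o3)c2)cc(OC)c1OC`, which keeps the shared core and the amide of compound 3. The change is this: 3,4,5-trimethoxyphenyl in place of 3-methoxyphenyl on an amide-type nitrogen. In words, a 3,4,5-trimethoxyphenyl stands in place of a 3-methoxyphenyl on an amide-type nitrogen.

Within the data shown here, no pair of measured compounds shows what a change on this nitrogen does, so neither the size nor the direction of a step can be read from the data. No step beyond the usual scatter is therefore expected in this assay, and the working guide is compound 2 at 1990 nM. With so little to go on, the range is kept wide, and a result without a number is also possible. For compound 4 the estimated value is 2000 nM, with an expected range of 400 nM to 10000 nM.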

Compound 4, half-maximal inhibitory concentration: 3400 nM
Compound 4: middle estimate off by 1.7-fold (0.23 log units), on the low side; measured number inside the range.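

In this assay, replacing the 2-methoxyphenyl on the amide-type nitrogen with a 3,4,5-trimethoxyphenyl gives a 1.7-fold higher number from compound 2 to compound 4 (0.23 log units; within the scatter), so this first readable comparison at the position shows that these two groups cannot be told apart here, even though the entering group carries more methoxy groups and is larger by the heavy-atom count. This comparison is the only one available, as compound 1 and compound 3 have no numbers and the steps involving them, including the direct change from compound 3 to compound 4, cannot be read. No measurement is at hand that would explain why the two aryl groups give values within the scatter of each other.

The compounds shown leave open whether the number of methoxy groups on this aryl ring matters at all, since the unsubstituted phenyl and the 3-methoxyphenyl cannot be set beside the two compounds with values. They also leave open how this assay would respond if a carboxylic acid or an amine stood on that ring, or if a cyclohexyl group took the place of the aryl ring on the amide-type nitrogen.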